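A few compounds are considered here, and "the series" means these few. Any claim that something is new, unique, unknown or untested is made for them only; others in the source may bear on it.

Of the compounds shown here, three have been measured in a functional assay on HEK293 cells for agonist activity at probable G-protein coupled receptor 27 (Homo sapiens), read by a luciferase reporter and beta-arrestin recruitment, with a stated time of 10 min; a higher number here means that more compound is needed for the effect, a lower number that less compound is needed. Compound 1 `O=C(Nc1cccc(S(=O)(=O)Nc2ccccc2)c1)c1ccc(Cl)cc1Cl` gives only a limit there, > 100000 nM. Compound 2 `CN(c1ccccc1)S(=O)(=O)c1ccc(NC(=O)c2ccc(Cl)cc2Cl)cc1` gives 2570 nM, the highest of the two numbers obtained. Compound 3 `O=C(Nc1ccc(S(=O)(=O)Nc2ccccc2)cc1)c1ccc(Br)cc1F` gives 479 nM, a lower number than compound 2 by a gap beyond the scatter. Compound 4 `Cc1ccc(NS(=O)(=O)c2ccc(NC(=O)c3ccc(Cl)cc3Cl)cc2)cc1` has not yet been measured; it differs from compound 2 in one place: (4-methylphenyl)amino in place of methyl(phenyl)amino on a sulfonyl sulfur. For the measured compounds named here, no measured step of exactly this kind exists, so the expectation rests on compound 3, whose group on the sulfonyl sulfur also holds a hydrogen-bond donor and which gives 479 nM. A downward step of moderate size, a 3.2-fold lower number from compound 2 to compound 4 (0.51 log units; beyond the scatter), is expected. Compound 4 is estimated to give 800 nM, between 250 nM and 2500 nM.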

Compound 4, half-maximal effective concentration: > 100000 nM
Compound 4: no number, only a limit (the forecaster's own chance of this, stated with the estimate: 10%); middle value at least 120-fold (2.09 log units) from the limit.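

In this assay, the group on the sulfonyl sulfur now proves to matter greatly: (4-methylphenyl)amino in place of methyl(phenyl)amino, the same atoms joined differently, gives an at least 38-fold higher number from compound 2 to compound 4 (1.59 log units; beyond the scatter). Compound 4 reads > 100000 nM, which is a limit of the assay and not a number. This limit is not unique to compound 4: the limit of > 100000 nM in this assay, at which 2 of the 4 values shown sit.

The change moves the methyl and adds a hydrogen-bond donor in one step, so the compounds shown cannot tell which of the two matters. A methyl(4-methylphenyl)amino group on the sulfonyl sulfur would separate them.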